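This account rests on a few compounds, and the source may have more. Where it says the series, first, only, none or still open, it means among the compounds named here.

The measured compounds, all in an ADME assay on BJ cells (Homo sapiens) for cytotoxicity, read by luminescence, with a stated time of 72 h; a lower number here means that less compound is needed, a higher number that more compound is needed for the effect:
Compound 1 `CCOC(=O)c1c(-c2cccc(-c3ccccc3)c2)[nH]c2cc(OC)ccc2c1=O` gives > 21500 nM, which is a limit of the assay.
Compound 2 `CCCCOc1cccc(-c2[nH]c3cc(OC)ccc3c(=O)c2C(=O)OCC)c1` gives > 21500 nM, which is a limit of the assay.
Compound 3 `CCOC(=O)c1c(-c2cccc(OC(F)(F)F)c2)[nH]c2cc(OC)ccc2c1=O` gives > 21500 nM, which is a limit of the assay.

Compound 3 therefore stands at the same limit as the other two compounds, and no number separates the three: the limit of > 21500 nM in this assay, at which 3 of the 3 values shown sit. The three measured steps that connect them say as much. The step that the two limits leave unreadable from compound 1 to compound 2, the step that the two limits leave unreadable from compound 1 to compound 3 and the step that the two limits leave unreadable from compound 2 to compound 3 all join two limits and so cannot be read in size or direction.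

Compound 4 `CCOC(=O)c1c(-c2cccc(NC(C)=O)c2)[nH]c2cc(OC)ccc2c1=O` differs from compound 3 in one place: acetamido in place of trifluoromethoxy on an aromatic carbon. Every measured step bears on this exchange only loosely, since each of them swaps one group at the same place on the outer ring and each ended at the limit, so none gives a readable size to carry over. The step that the limit leaves unreadable from compound 3 to compound 4 is thus expected to remain hidden behind the limit as well, with no readable direction. Compound 4 is estimated at 30000 nM in this assay, within a range from 12000 nM to 90000 nM, and most probably reported again only as a limit.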

Compound 4, half-maximal effective concentration: > 21500 nM
Compound 4: only a limit was reported; the forecaster's own chance of this, stated with the estimate: 85%; the middle value is on the limit's open side.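

In this assay compound 4 gives > 21500 nM, a limit of the assay, so its steps from compound 1, compound 2 and compound 3 cannot be read in size or direction. All four compounds now share one limit: the limit of > 21500 nM in this assay, at which 4 of the 4 values shown sit.

The compounds shown leave open how far apart they truly lie in this assay, and whether any exchange at this place changes the value at all.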